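N-acylation of the ring nitrogen in compound 2

A few compounds are considered here, and "the series" means these few. Any claim that something is new, unique, unknown or untested is made for them only; others in the source may bear on it.

Measured compounds in an assay on HEK293 cells for antagonist activity at Voltage-dependent L-type calcium channel subunit alpha-1C (Oryctolagus cuniculus), read by FLIPR; on this read-out higher numbers stand for weaker inhibition and lower numbers for stronger inhibition:
compound 1 `COC(=O)C1=C(C)NC(=O)NC1c1cccc([N+](=O)[O-])c1` gives 11700 nM
compound 2 `CC1=C(C(=O)OC(C)C)C(c2cccc([N+](=O)[O-])c2)NC(=O)N1` gives 58100 nM
compound 3 `CC1=C(C(=O)OC(C)C)C(c2cccc([N+](=O)[O-])c2)NC(=S)N1` gives 10700 nM

Compound 2 stands at the highest of the three numbers in this assay, with compound 1 and compound 3 both giving lower numbers by steps beyond the scatter. Going by the values given here, the only single-point step measured is a 5.0-fold higher number from compound 1 to compound 2 (0.70 log units; beyond the scatter), an ester change that leaves the ring nitrogens untouched. Compound 4 `CC1=C(C(=O)OC(C)C)C(c2cccc([N+](=O)[O-])c2)N(C(=O)C(C)C)C(=O)N1` differs from compound 2 as follows: isopropylcarbonyl in place of hydrogen on an amide-type nitrogen in a ring. Among the compounds with values here, no measured step alters this nitrogen, so nothing in the data speaks directly to the size or direction of the change in this assay. The shared core has so far produced numbers in a fairly narrow band, and without a precedent for substitution at the ring nitrogen a step of a 1.9-fold lower number from compound 2 to compound 4 (0.29 log units; within the scatter) is expected, with wide uncertainty in either direction. Compound 4 is therefore estimated at 30000 nM, within a range of 8000 nM to 110000 nM, in this assay.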

Compound 4, half-maximal inhibitory concentration: 500 nM
Beside the measured number, compound 4's estimate is 60-fold (1.78 log units) above it, outside the stated range (below it).
By their numbers in this assay, from the lowest: compound 4; then compounds 3 and 1 (each within the scatter of the next); then compound 2.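

In this assay, putting isopropylcarbonyl in place of hydrogen on the amide-type nitrogen in the ring gives a 120-fold lower number from compound 2 to compound 4 (2.07 log units; beyond the scatter). Going by these compounds alone, this is the first measured change at this nitrogen, and it shows that the position is highly sensitive to substitution. It also shows that the hydrogen there is not needed for inhibition, since a group of 5 heavy atoms in its place lowers the number rather than raising it. No evidence at hand bears on why the step is so large. The compounds shown leave open whether the gain depends on the carbonyl or on the isopropyl part, which an acetyl group, a simple methyl or a longer acyl chain on this nitrogen would help to separate. They also leave open whether the same acylation would give a similar step on compound 1 or compound 3.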